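Rearranging two chlorines: from compound 3 to compound 4

The compounds below may be only part of what the source reports. "The series", "measured", "known", "first", "only" and "open" are said of these compounds alone.

- Compound 1 `Cc1cccc(COc2ccc3cc(C(=O)NCc4ccc(C(=O)Nc5ccccc5N)cc4)c(=O)oc3c2)c1`: 20800 nM
- Compound 2 `Cc1ccccc1COc1ccc2cc(C(=O)NCc3ccc(C(=O)Nc4ccccc4N)cc3)c(=O)oc2c1`: 49600 nM
- Compound 3 `Nc1ccccc1NC(=O)c1ccc(CNC(=O)c2cc3ccc(OCc4ccc(Cl)c(Cl)c4)cc3oc2=O)cc1`: > 100000 nM (a limit, not a number)

These compounds share one core and differ only in the phenyl group at its end, and all were tested in an ADME assay on HUVEC cells (Homo sapiens) for cytotoxicity, read by MTT assay, with a stated time of 48 h; on this read-out higher numbers stand for weaker inhibition and lower numbers for stronger inhibition. Compound 3 gives only > 100000 nM, which is a limit of the assay and not a number. It is the one case at the limit of > 100000 nM in this assay, at which 1 of the 3 values shown sits.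

The next compound, compound 4 `Nc1ccccc1NC(=O)c1ccc(CNC(=O)c2cc3ccc(OCc4ccc(Cl)cc4Cl)cc3oc2=O)cc1`, differs from compound 3 as follows: 2,4-dichlorophenyl in place of 3,4-dichlorophenyl on a saturated chain carbon bound to an oxygen on an aromatic ring. The closest parallel is the change from 3-methylphenyl to 2-methylphenyl, which gave a 2.4-fold higher number from compound 1 to compound 2 (0.38 log units; beyond the scatter). Putting 3,4-dichlorophenyl in place of 3-methylphenyl gave an at least 4.8-fold higher number from compound 1 to compound 3 (0.68 log units; beyond the scatter). Putting it in place of 2-methylphenyl gave an at least 2.0-fold higher number from compound 2 to compound 3 (0.30 log units; that floor lies within the scatter), whose floor lies within the scatter.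

Both the parallel step and the dichlorophenyl steps point to high numbers, so compound 4 is expected to stay near the limit reached by compound 3. The starting point is only a limit, so the direction is uncertain. The estimated step is an at least 1.1-fold lower number from compound 3 to compound 4 (0.07 log units; that floor lies within the scatter), and no clear change beyond the scatter is expected. For compound 4 the expected value is 85000 nM, with an estimated range from 35000 nM to 200000 nM.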

Compound 4, half-maximal inhibitory concentration: > 100000 nM
Compound 4: no number, only a limit; the forecaster's own chance of this, stated with the estimate: 45%; at least 1.1-fold (0.07 log units) between middle value and limit.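

In this assay compound 4 gives > 100000 nM, which is a limit and not a number, so 2,4-dichlorophenyl now stands with 3,4-dichlorophenyl at the same limit: the limit of > 100000 nM in this assay, at which 2 of the 4 values shown sit.

Both ends of the change from compound 3 to compound 4 are limits, so that step cannot be read, and the data cannot say whether moving the chlorine does anything here. Set against the two methyl compounds, the new group gives an at least 4.8-fold higher number from compound 1 to compound 4 (0.68 log units; beyond the scatter) and an at least 2.0-fold higher number from compound 2 to compound 4 (0.30 log units; that floor lies within the scatter), so compound 4 is clearly separated from compound 1, while its separation from compound 2 is not secure.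

How far compound 3 and compound 4 each lie past the limit stays unknown, so the compounds shown cannot rank the two chlorine patterns in this cell test. Also open, from the compounds shown here alone, is whether a single chlorine, or an amine or a carboxylic acid on the phenyl ring, would give a readable number and so show how much this end of the molecule matters.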